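The compounds below may be only part of what the source reports. "The series", "measured", "known", "first", "only" and "open" are said of these compounds alone.

In a functional assay on HeLa cells (Homo sapiens) for antiproliferative activity, read by MTT assay, with a stated time of 72 h (on this read-out higher numbers stand for weaker inhibition and lower numbers for stronger inhibition), compound 1 `COc1cc(-c2nccn2C(C)C)cc(OC)c1OC` gives > 100000 nM, which is a limit of the assay and not a number. Compound 2 `COc1cc(-c2nccn2Cc2ccccc2)cc(OC)c1OC` gives > 100000 nM, also a limit. Compound 3 `COc1cccc(-n2ccnc2-c2cc(OC)c(OC)c(OC)c2)c1` differs from compound 2 as follows: 3-methoxyphenyl in place of benzyl on an aromatic nitrogen. In words, 3-methoxyphenyl stands in place of benzyl on an aromatic nitrogen. Within the data shown here, the only measured step at this nitrogen is a step that the two limits leave unreadable from compound 1 to compound 2, so its size offers no guide, and the evidence so far is the limit of > 100000 nM in this assay, at which 2 of the 2 values shown sit. With no number to go on, only a modest move towards stronger inhibition is expected, and the estimated step is an at least 5.0-fold lower number from compound 2 to compound 3 (0.69 log units; beyond the scatter). For compound 3 the expected value is 20000 nM, with an estimated range from 2000 nM to 100000 nM.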

Compound 3, half-maximal inhibitory concentration: 11000 nM
Beside the measured number, compound 3's estimate is 1.8-fold (0.26 log units) above it, and the stated range covers the measured number.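

In this assay, compound 1 and compound 2 left no readable step at this aromatic nitrogen, since both stop at a limit of the assay: the limit of > 100000 nM in this assay, at which 2 of the 3 values shown sit.

Compound 3 shows that a change at this nitrogen can bring a measurable value: 3-methoxyphenyl in place of benzyl gives an at least 9.0-fold lower number from compound 2 to compound 3 (0.95 log units; beyond the scatter), and in place of isopropyl it gives an at least 9.0-fold lower number from compound 1 to compound 3 (0.95 log units; beyond the scatter). The ring now sits on the nitrogen without the carbon link of benzyl and also carries a methoxy group, so these two changes arrive together.

Which of them matters stays open. Also open, going by these compounds, is what a plain phenyl, or a phenyl bearing an amine or a carboxylic acid, would do at this nitrogen.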